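The source may hold more compounds than are shown below. What is called first, only, known or untested is meant among the compounds shown, and "the series" means these compounds.

Compound 1 has the structure `CC(=O)OCCOn1cnc2c(S)nc(F)nc21` and compound 2 the structure `CC(O)n1cnc2c(S)nc(F)nc21`; the two share one core and differ only in the group carried on an aromatic nitrogen of the five-membered ring. In a functional assay on HEp-2 cells (Homo sapiens) for inhibition (a lower number here means a stronger inhibitor, a higher number a weaker inhibitor), compound 1 gives > 500000 nM, which is a limit of the assay and not a measured number. In this assay compound 2 likewise gives > 500000 nM, again a limit rather than a number. Going by the values given here, compound 2 therefore stands at the edge of what the assay can report, as the limit of > 500000 nM in this assay, at which 2 of the 2 values shown sit, shows, and nothing measured so far sits anywhere else.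

The unmeasured compound 3 has the structure `OCCOn1cnc2c(S)nc(F)nc21`. It differs from compound 2 by 2-hydroxyethoxy in place of 1-hydroxyethyl on an aromatic nitrogen. Among the compounds with values here, no step between two measured compounds exists here, so no measured pair tells how large a change of this kind is in this assay; both known values are limits.

With both neighbours at the limit, the step of a number no higher from compound 2 to compound 3 (the limit leaves the size open) is expected to be none beyond the scatter. Compound 3 is expected to give about 500000 nM in this assay, estimated to fall between 200000 nM and 1000000 nM.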

Compound 3, half-maximal inhibitory concentration: > 500000 nM
Compound 3 ended at the assay's limit (the forecaster's own chance of this, stated with the estimate: 85%); the middle value lies on the limit itself.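

Compound 3 gives > 500000 nM in this assay, which is a limit of the assay and not a number. Going by these compounds alone, compound 1 and compound 2 also sit at a limit, so no step to compound 3 can be read. The compounds shown leave open whether any change on the shared core alters inhibition, as all of them stand at one value: the limit of > 500000 nM in this assay, at which 3 of the 3 values shown sit.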